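The compounds below may be only part of what the source reports. "The series", "measured", "known", "first", "only" and "open" are said of these compounds alone.

Compound 1 `O=c1ncn(Cc2c(F)cc(F)cc2F)c2ccc(Oc3cccc(-c4ccc5[nH]ccc5c4)c3C(F)(F)F)cc12` and compound 2 `O=c1ncn(Cc2c(F)cc(F)cc2F)c2ccc(Oc3cccc(-c4ccc5[nH]cnc5c4)c3C(F)(F)F)cc12` share the same core and differ only in the bicyclic group on the aromatic carbon. In a physicochemical assay for solubility, using the shake flask method, with a stated time of 24 h, at pH 2 (a lower number here means a less soluble compound, a higher number a more soluble compound), compound 1 gives only the limit < 0.1 ug/mL. In this assay compound 2 likewise gives only the limit < 0.1 ug/mL, so where compound 2 stands among the numbers shown is a limit and not a measured number. The step that the two limits leave unreadable from compound 1 to compound 2 is accordingly not readable, because of the limit of < 0.1 ug/mL in this assay, at which 2 of the 2 values shown sit. Compound 3 `O=c1ncn(Cc2c(F)cc(F)cc2F)c2ccc(Oc3cccc(-c4ccc5cc[nH]c5c4)c3C(F)(F)F)cc12` is the next member of the series: 1H-indol-6-yl in place of 1H-benzimidazol-5-yl on an aromatic carbon. For the measured compounds named here, the only measured step that bears on this change is the unreadable one from compound 1 to compound 2, so nothing in this assay supports expecting a step of any size or direction away from the limit. Compound 3 is therefore expected to sit at 0.05 ug/mL, with a range from 0.01 ug/mL to 0.15 ug/mL. The step that the limit leaves unreadable from compound 2 to compound 3 expected is essentially none.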

Compound 3, solubility: < 0.1 ug/mL
Compound 3 was reported as a limit (the forecaster's own chance of this, stated with the estimate: 90%); the middle value is on the limit's open side.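

No step among compound 1, compound 2 and compound 3 can be read in this assay, because each is reported only as a limit: the limit of < 0.1 ug/mL in this assay, at which 3 of the 3 values shown sit.

The compounds shown leave open whether 1H-indol-5-yl, 1H-benzimidazol-5-yl and 1H-indol-6-yl differ at all in this assay.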